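The compounds below may be only part of what the source reports. "The series", "measured", "known", "first", "only" and "open" are said of these compounds alone.

Compound 1 `O=C(O)CCNC(=O)CCCSC[C@H](NC(=O)OCc1ccccc1)C(=O)Nc1ccccc1` carries a carboxy on a saturated chain carbon, two bonds along the chain from an amide-type nitrogen. Within the data shown here, in an assay for inhibition of NAD-dependent protein deacylase sirtuin-6 (Homo sapiens), read by HPLC, with stated times of 15 min and 1 h, tested at 333 uM (on this read-out higher numbers stand for more inhibition at the one concentration tested (going by the name of the read-out) and lower numbers for less inhibition), compound 1 gives 43%, the highest of the three numbers so far, though only its step to compound 3 is beyond the scatter. Compound 2 `O=C(O)CCCNC(=O)CCCSC[C@H](NC(=O)OCc1ccccc1)C(=O)Nc1ccccc1` gives 35% in this assay, and compound 3 `CCCCCCCCCCCCCNC(=O)CCCSC[C@H](NC(=O)OCc1ccccc1)C(=O)Nc1ccccc1` gives 31%. The step of a number 8 percentage points lower from compound 1 to compound 2 (within the scatter) stays within the scatter, while a number 12 percentage points lower from compound 1 to compound 3 (beyond the scatter) goes beyond it; between compounds 2 and 3 the step of a number 4 percentage points lower from compound 2 to compound 3 (within the scatter) is within the scatter again.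

Compound 4 `CCNC(=O)CCCSC[C@H](NC(=O)OCc1ccccc1)C(=O)Nc1ccccc1` is not yet measured. Its change from compound 1 is hydrogen in place of carboxy on a saturated chain carbon, two bonds along the chain from an amide-type nitrogen. Both steps that move or replace the carboxy of compound 1 bear on it: the shift in a number 8 percentage points lower from compound 1 to compound 2 (within the scatter) and the replacement in a number 12 percentage points lower from compound 1 to compound 3 (beyond the scatter). Removing the carboxy outright is expected to land in the same range, a small to modest drop in this assay, expected as a number 10 percentage points lower from compound 1 to compound 4 (within the scatter). Compound 4 is therefore estimated at 33%, within 20% to 45%.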

Compound 4, a percentage reported as inhibition, at one concentration (the size of the read-out at that concentration, not a potency): 15%
Compound 4: middle estimate off by 18 percentage points, on the high side, outside the stated range (below it).
By their numbers in this assay, from the lowest: compound 4; then compounds 3, 2 and 1 (each within the scatter of the next, the first and the last beyond it).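

In this assay, hydrogen in place of the substituent on a saturated chain carbon, two bonds along the chain from an amide-type nitrogen, gives a number 28 percentage points lower from compound 1 to compound 4 (beyond the scatter) and a number 20 percentage points lower from compound 2 to compound 4 (beyond the scatter) and also a number 16 percentage points lower from compound 3 to compound 4 (beyond the scatter) in the same series. Carboxy, carboxymethyl and undecyl at this place all stand above hydrogen, so the loss is not tied to the carboxy alone: compound 3, which carries no carboxylic acid, also stays above compound 4. No measurement at hand speaks to the reason for this drop.

On these data alone, whether a short chain such as propyl or butyl at this place already recovers the number, or only a longer one does, stays open. Also open, as far as these compounds go, is whether an amine or a primary amide in place of the carboxy matches compound 1.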